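Replacing the 2-fluoropyridin-3-yl group of compound 2

This account rests on a few compounds, and the source may have more. Where it says the series, first, only, none or still open, it means among the compounds named here.

For the measured compounds named here, in a physicochemical assay for solubility, measured as kinetic solubility, with a stated time of 1 h, at pH 7.4 (on this read-out lower numbers stand for lower solubility and higher numbers for higher solubility), compound 2 (`O=C(NC1=NN(c2ccc(Cl)c(Cl)c2)CC1)c1cccnc1F`) gives 13000 nM, the lower of the two numbers so far, and compound 1 (`O=C1CCCC(C(=O)NC2=NN(c3ccc(Cl)c(Cl)c3)CC2)N1`) gives 416000 nM. Compound 3 (`Cc1ncncc1C(=O)NC1=NN(c2ccc(Cl)c(Cl)c2)CC1`) carries 4-methylpyrimidin-5-yl in place of 2-fluoropyridin-3-yl on a carbonyl carbon. Going by the values given here, one measured step touches the same place: a 32-fold lower number from compound 1 to compound 2 (1.51 log units; beyond the scatter). That step is large, but it exchanges a different pair of groups, so it shows only that this place can move the number widely. Here one six-membered aromatic ring replaces another, so a much smaller change is expected, towards a higher number. The expected move is a 2.7-fold higher number from compound 2 to compound 3 (0.43 log units; beyond the scatter). For compound 3 the estimated value in this assay is 35000 nM, with an expected range from 12000 nM to 120000 nM.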

Compound 3, solubility: 12000 nM
The estimate for compound 3 lay 2.9-fold (0.46 log units) above the measured number; the measured number falls inside the stated range.
By their numbers in this assay, from the lowest: compounds 3 and 2 (each within the scatter of the next); then compound 1.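

In this assay, 4-methylpyrimidin-5-yl in place of 2-fluoropyridin-3-yl on the carbonyl carbon gives a 1.1-fold lower number from compound 2 to compound 3 (0.03 log units; within the scatter), so this exchange of one six-membered aromatic ring for another, with 2 hetero atoms in place of 1 and 2 hydrogen-bond acceptors in place of 1, leaves the read-out within the scatter. The step from the 6-oxopiperidin-2-yl group to the second aromatic ring is a 35-fold lower number from compound 1 to compound 3 (1.54 log units; beyond the scatter), so the large move at this place now appears with two different aromatic groups, not just one. Nothing on hand gives a reason for either step.

As far as these compounds go, it remains open what a simple amine or a carboxylic acid on a longer chain at the same carbonyl carbon would give. From the compounds shown here alone, it also remains open whether any other aromatic ring there would depart from compound 2 and compound 3.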